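Swapping Bromo for Cyano on a Second Core

The source may report more compounds than this note shows. Statements on the series, on what has been measured and on what is new or still open speak of the compounds shown alone.

Compound 1 `COc1cc([C@](O)(CCN(C)C)[C@@H](c2cc3cc(Br)ccc3nc2OC)c2ccnc(OC)c2OC)cc(OC(F)F)n1` and compound 2 `COc1cc([C@](O)(CCN(C)C)[C@@H](c2cc3cc(C#N)ccc3nc2OC)c2ccnc(OC)c2OC)cc(OC(F)F)n1` share one core and differ in a single place: cyano in place of bromo on an aromatic carbon. In an ADME assay on the whole organism (Mus musculus, strain CD-1) for pharmacokinetics (a lower number here means slower removal, a higher number faster removal of the compound), compound 1 gives 8.7 mL/min/kg, while compound 2 gives 24 mL/min/kg, so this change brought a 2.8-fold higher number from compound 1 to compound 2 (0.44 log units; beyond the scatter). Compound 3 `COc1cc([C@](O)(CCN(C)C)[C@@H](c2cc3cc(Br)ccc3nc2OC)c2cccc(OC)c2F)cc(SC)n1` carries the bromo on another core; the difference between the two cores is not broken down here. In this assay compound 3 gives 13 mL/min/kg. Compound 4 `COc1cc([C@](O)(CCN(C)C)[C@@H](c2cc3cc(C#N)ccc3nc2OC)c2cccc(OC)c2F)cc(SC)n1` is the same change applied to compound 3: cyano in place of bromo on an aromatic carbon. Going by the values given here, because the only earlier instance of this change produced a 2.8-fold higher number from compound 1 to compound 2 (0.44 log units; beyond the scatter), a step of similar size is expected here, namely a 2.5-fold higher number from compound 3 to compound 4 (0.39 log units; beyond the scatter). On that basis compound 4 is estimated at 32 mL/min/kg, with a plausible range from 16 mL/min/kg to 60 mL/min/kg.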

Compound 4, clearance: 42 mL/min/kg
Beside the measured number, compound 4's estimate is 1.3-fold (0.12 log units) below it; the range from low to high includes it.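

In this assay, putting cyano in place of bromo gave a 3.2-fold higher number from compound 3 to compound 4 (0.51 log units; beyond the scatter), and the same swap on the other core moved the number in the same direction by a similar amount: the same change on two cores in this assay, a 2.8-fold higher number (0.44 log units; beyond the scatter) from compound 1 to compound 2 and a 3.2-fold higher number (0.51 log units; beyond the scatter) from compound 3 to compound 4, 1.2-fold (0.07 log units) apart, within the scatter of two such steps. In these two pairs, then, the change carried over from one core to the other in both direction and size. Two pairs are a small sample, however: they do not show that the step would hold on further cores in this series, and they do not explain why the number rises.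

The compounds shown leave open what other groups on this aromatic carbon, such as a chloro, a methyl or a carboxylic acid, would do to the number. Also open, going by these compounds, is how the two cores compare on their own, as compound 1 and compound 3 differ in more than one place.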